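The compounds below may be only part of what the source reports. "The series", "measured", "known", "first", "only" and "open" are said of these compounds alone.

Working notes on the series. In an ADME assay on the whole organism (Macaca fascicularis) for pharmacokinetics, read by LC-MS, using cassette dosing, at a dose of 1 mg/kg by the oral route (on this read-out lower numbers stand for lower exposure and higher numbers for higher exposure at the dose given), compound 1 `CCCCN(c1nc2c(NC(C)=O)cccc2o1)[C@H](C)c1ccc(-c2ccccc2-c2nnn[nH]2)cc1` gives 26.6 nM, compound 2 `C[C@H](c1ccc(-c2cc(F)ccc2-c2nc(=O)o[nH]2)cc1)N(CC1CC1)c1nc2c(C(=O)O)cccc2o1` gives 2900 nM, and compound 3 `CCCCN(c1nc2c(C(=O)N(C)C)cccc2o1)[C@H](C)c1ccc(-c2ccccc2-c2nnn[nH]2)cc1` gives 54 nM. Compound 3 therefore stands second highest of the three numbers; its nearest neighbour is compound 1, and compound 2 stands far above it. Among the measured compounds shown here, the one single-point step within the set, a 2.0-fold higher number from compound 1 to compound 3 (0.31 log units; beyond the scatter), is modest. Compound 4 `CCCCN(c1nc2c(-c3ccccn3)cccc2o1)[C@H](C)c1ccc(-c2ccccc2-c2nnn[nH]2)cc1` carries pyridin-2-yl in place of dimethylcarbamoyl on an aromatic carbon on an aromatic carbon of the core shared with compound 3. For the measured compounds named here, no measured step exchanges the dimethylcarbamoyl for a ring at this position, and compound 2 differs in several places at once, so the step to compound 4 has no direct precedent. Given the small size of the step from compound 1 to compound 3, no more than a modest change is expected: compound 4 is estimated at 60 nM, within 15 nM to 250 nM, an expected 1.1-fold higher number from compound 3 to compound 4 (0.05 log units; within the scatter).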

Compound 4, maximal plasma concentration: 124 nM
The estimate for compound 4 lay 2.1-fold (0.32 log units) below the measured number; the measured number falls inside the stated range.
By their numbers in this assay, from the lowest: compound 1; then compound 3; then compound 4; then compound 2.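

In this assay this aromatic carbon now carries a ring rather than an open-chain amide group, and exposure does not suffer: pyridin-2-yl gives a 2.3-fold higher number from compound 3 to compound 4 (0.36 log units; beyond the scatter) and also a 4.7-fold higher number from compound 1 to compound 4 (0.67 log units; beyond the scatter). Among the compounds that differ only here, the order runs acetamido, dimethylcarbamoyl, pyridin-2-yl, each step modest. Nothing on hand accounts for this order.

Still open, going by these compounds, is whether the ring nitrogen matters, which a plain phenyl ring at this carbon would test. Also open, on these data alone, is where a primary amine would fall in this order.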